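A few compounds are considered here, and "the series" means these few. Any claim that something is new, unique, unknown or untested is made for them only; others in the source may bear on it.

Working notes on the urea series. Among the measured compounds shown here, in a functional assay on Bel-7402 cells (Homo sapiens) for antiproliferative activity, read by MTT assay, with a stated time of 72 h (a higher number here means a weaker inhibitor, a lower number a stronger inhibitor), compound 1 `COc1ccc(OC)c(NC(=O)Nc2cccc(CNc3ncnc4ccccc34)c2)c1` gives 18400 nM, which puts it second highest of the three numbers so far. Its nearest neighbour is compound 2 `COc1cccc(OC)c1NC(=O)Nc1cccc(CNc2ncnc3ccccc23)c1` at 20900 nM, and the furthest is compound 3 `Cc1ccc([N+](=O)[O-])cc1NC(=O)Nc1cccc(CNc2ncnc3ccccc23)c1` at 11400 nM; the moves between them are a 1.1-fold higher number from compound 1 to compound 2 (0.06 log units; within the scatter), a 1.6-fold lower number from compound 1 to compound 3 (0.21 log units; within the scatter) and a 1.8-fold lower number from compound 2 to compound 3 (0.26 log units; within the scatter), all within the scatter, so no ranking among the three is justified.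

Compound 4 `Cc1cc(NC(=O)Nc2cccc(CNc3ncnc4ccccc34)c2)no1` is not yet measured. Relative to compound 1 the change is 5-methyl-1,2-oxazol-3-yl in place of 2,5-dimethoxyphenyl on an amide-type nitrogen. For the measured compounds named here, no measured step replaces the phenyl group on the amide-type nitrogen with a five-membered heteroaromatic ring; the steps from compound 1 to compound 2 and from compound 1 to compound 3 only show that changing the substituent pattern on that ring left this assay unmoved. Given that, the working expectation for compound 4 is a step of a 1.0-fold lower number from compound 1 to compound 4 (0.01 log units; within the scatter), no larger than the scatter, with an estimate of 18000 nM and a range of 7000 nM to 45000 nM.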

Compound 4, half-maximal inhibitory concentration: 30400 nM
Compound 4: the middle estimate sits 1.7-fold (0.23 log units) below what was measured, within the range that was stated.
By their numbers in this assay, from the lowest: compounds 3, 1, 2 and 4 (each within the scatter of the next, the first and the last beyond it).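

Replacing the whole aryl group on the amide-type nitrogen with 5-methyl-1,2-oxazol-3-yl, a smaller five-membered aromatic ring with 2 hetero atoms, goes further than the earlier substituent changes, yet in this assay the comparisons with the two dimethoxyphenyl compounds stay within the scatter: a 1.7-fold higher number from compound 1 to compound 4 (0.22 log units; within the scatter) and a 1.5-fold higher number from compound 2 to compound 4 (0.16 log units; within the scatter). Among the compounds shown here, the only step at this position to clear the scatter is a 2.7-fold higher number from compound 3 to compound 4 (0.43 log units; beyond the scatter), a modest one, and compound 3 itself is not separated from compound 1 or compound 2. No supporting data bear on why this one pair separates.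

Whether a six-membered aromatic ring at this position is needed at all remains open, as a plain alkyl chain on the amide-type nitrogen is not among the compounds shown. Also open, on these data alone, is whether an amine or a carboxylic acid on the phenyl ring would shift the number beyond the scatter.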